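The compounds below may be only part of what the source reports. "The series", "measured", "known", "first", "only" and "open" are said of these compounds alone.

Among the compounds with values here, compound 2 `Clc1ccc(-c2cc(-c3ccc(Cl)o3)cc(-c3ccsc3)n2)cc1` holds the only number in the set: in a functional assay on HeLa cells (Homo sapiens) for cytotoxicity, in the presence of a further agent that is not named here (on this read-out higher numbers stand for weaker inhibition and lower numbers for stronger inhibition), compound 2 gives 8410 nM. Compound 1 `Clc1ccc(-c2cc(-c3ccsc3)nc(-c3ccco3)c2)o1` gives in this assay > 50000 nM, which is a limit of the assay (the limit of > 50000 nM in this assay, at which 1 of the 2 values shown sits). The step of an at least 5.9-fold lower number from compound 1 to compound 2 (0.77 log units; beyond the scatter) is the sole measured one. Compound 3 `Clc1ccc(-c2cc(-c3ccc(Cl)o3)cc(-c3cccs3)n2)cc1` differs from compound 2 by thiophen-2-yl in place of thiophen-3-yl on an aromatic carbon. The measured step concerns another change and does not bear on this one, so for compound 3 no shift beyond the scatter is expected, an estimated 1.0-fold lower number from compound 2 to compound 3 (0.00 log units; within the scatter). Compound 3 is expected at 8400 nM, within 3000 nM to 25000 nM.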

Compound 3, half-maximal inhibitory concentration: 21300 nM
Compound 3: middle estimate off by 2.5-fold (0.40 log units), on the low side; the measured number falls inside the stated range.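

Thiophen-2-yl in place of thiophen-3-yl gives a 2.5-fold higher number from compound 2 to compound 3 (0.40 log units; beyond the scatter), so the position next to the ring nitrogen responds to a change of attachment point alone, with the same atoms and the same counts. The earlier step concerned a different change, 4-chlorophenyl in place of furan-2-yl. Nothing shown gives a cause for this shift.

Open, from the compounds shown here alone, is how an amine or a carboxylic acid in place of the thiophene would read in this assay. Also open, going by these compounds, is whether this shift holds with furan-2-yl in place of the 4-chlorophenyl group.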